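A few compounds are considered here, and "the series" means these few. Any claim that something is new, unique, unknown or untested is made for them only; others in the source may bear on it.

Compound 1 `CC(O)(CSc1cccc(C(F)(F)F)c1)C(=O)Nc1ccc(S(F)(F)(F)(F)F)cc1` — 18300 nM
Compound 2 `CC(O)(CSc1cc(C(F)(F)F)cc(C(F)(F)F)c1)C(=O)Nc1ccc(S(F)(F)(F)(F)F)cc1` — 17600 nM
Compound 3 `CC(O)(COc1cccc(C(F)(F)F)c1)C(=O)Nc1ccc(S(F)(F)(F)(F)F)cc1` — 24700 nM

In a functional assay on LNCaP cells (Homo sapiens) for antiproliferative activity, read by propidium iodide staining, with a stated time of 96 h (a lower number here means a stronger inhibitor, a higher number a weaker inhibitor), compound 1 gives 18300 nM and compound 2 gives 17600 nM; the two values lie within the scatter of each other. Compound 2 differs from compound 1 by trifluoromethyl in place of hydrogen on an aromatic carbon, and that change made a 1.0-fold lower number from compound 1 to compound 2 (0.02 log units; within the scatter). Compound 3 gives 24700 nM in this assay; how its core differs from the core of compound 1 is not broken down here.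

Compound 4 `CC(O)(COc1cc(C(F)(F)F)cc(C(F)(F)F)c1)C(=O)Nc1ccc(S(F)(F)(F)(F)F)cc1` has not yet been measured. It differs from compound 3 by trifluoromethyl in place of hydrogen on an aromatic carbon, the same change as that from compound 1 to compound 2, at the same kind of place. For compound 4 the step of a 1.0-fold lower number from compound 3 to compound 4 (0.01 log units; within the scatter) is expected to be small because a 1.0-fold lower number from compound 1 to compound 2 (0.02 log units; within the scatter) showed almost no movement. Compound 4 is therefore estimated at 24000 nM in this assay, expected to fall between 12000 nM and 50000 nM.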

Compound 4, half-maximal inhibitory concentration: 2300 nM
Compound 4: middle estimate off by 10-fold (1.02 log units), on the high side; measured number outside the range, below it.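

In this assay, the same change did not carry over evenly from one core to the other: the same change on two cores in this assay, a 1.0-fold lower number (0.02 log units; within the scatter) from compound 1 to compound 2 and an 11-fold lower number (1.03 log units; beyond the scatter) from compound 3 to compound 4, 10-fold (1.01 log units) apart, beyond the scatter of two such steps It gave an 11-fold lower number from compound 3 to compound 4 (1.03 log units; beyond the scatter), whereas on the other core it gave a 1.0-fold lower number from compound 1 to compound 2 (0.02 log units; within the scatter). The two pairs show that the size of this step depends on the core it is made on, but they do not show why the steps differ, nor what the change would do on any further core.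

The compounds shown leave open whether a chlorine, a nitrile or a methyl group at the same place would give a step like that of trifluoromethyl. They also leave open how an amine in place of the hydroxyl would affect these values.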